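The source may hold more compounds than are shown below. What is called first, only, known or untested is meant among the compounds shown, and "the series" means these compounds.

In a functional assay on HOS-TE85 cells (Homo sapiens) for inhibition, read by CCK-8 assay, with a stated time of 72 h, tested at 1 uM (on this read-out higher numbers stand for more inhibition at the one concentration tested (going by the name of the read-out) and lower numbers for less inhibition), compound 2 `Cc1cccc(N2C(=O)CSC2c2cccc(C(=O)NCCCCc3ccccc3)c2)c1` gives 96%. Compound 1 `COc1ccc(C)cc1N1C(=O)CSC1c1cccc(C(=O)NCCCCc2ccccc2)c1` carries a methoxy where compound 2 carries hydrogen. In this assay compound 1 gives 95%, and the step of a number 1 percentage points higher from compound 1 to compound 2 (within the scatter) is within the scatter, so compound 2 stands alongside compound 1 with the two numbers indistinguishable at this concentration.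

Compound 3 `O=C(NCCCCc1ccccc1)c1cccc(C2SCC(=O)N2c2cccc(F)c2)c1` differs from compound 2 by fluoro in place of methyl on an aromatic carbon. Within the data shown here, no measured step concerns a fluoro or a methyl on that ring, so the only guide is the one step recorded: it was small, which suggests a change of substituent at this part of the structure leaves the number level. Both measured numbers are high on the percentage scale, leaving little room to rise. Compound 3 is therefore expected to show a step of a number 3 percentage points lower from compound 2 to compound 3 (within the scatter) that stays within the scatter. The estimate for compound 3 in this assay is 93%, with a range from 80% to 99%.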

Compound 3, a percentage reported as inhibition, at one concentration (the size of the read-out at that concentration, not a potency): 94%
The estimate for compound 3 lay 1 percentage points below the measured number; the measured number falls inside the stated range.
By their numbers in this assay, from the lowest: compounds 3, 1 and 2 (each within the scatter of the next).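

In this assay, fluoro in place of methyl on the aromatic ring, meta to a large group, gives a number 2 percentage points lower from compound 2 to compound 3 (within the scatter) and so leaves the 3-methylphenyl and 3-fluorophenyl forms indistinguishable at the one concentration tested. Putting 3-fluorophenyl in place of the whole 2-methoxy-5-methylphenyl on the amide-type nitrogen gives a number 1 percentage points lower from compound 1 to compound 3 (within the scatter) and shows that a change of both the group and its pattern of substitution also stays within the scatter. Nothing at hand accounts for this level result.

All three numbers lie high on the percentage scale at a single concentration, so any difference in potency among these compounds remains open. Also open, from the compounds shown here alone, is whether an amine or a carboxylic acid on this ring would leave the number level.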